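Swapping 4-methylphenyl for methyl on compound 2

The compounds below may be only part of what the source reports. "The series", "measured", "known", "first", "only" and "open" are said of these compounds alone.

Measured in an ADME assay on cells (Hepatocyte, Mus musculus) for metabolic stability; a lower number here means that the compound disappears faster, a higher number that the compound lasts longer:
- compound 1 `CS(=O)(=O)NC1CCC(CN2CCN(c3cc(=O)c4cc(C(F)(F)F)cc([N+](=O)[O-])c4s3)CC2)CC1`: > 1.55 h (a limit of the assay)
- compound 2 `Cc1ccc(C(=O)OC2CCC(CN3CCN(c4cc(=O)c5cc(C(F)(F)F)cc([N+](=O)[O-])c5s4)CC3)CC2)cc1`: 0.202 h

For the measured compounds named here, compound 2 holds the only true number so far, 0.202 h. Compound 3 `CC(=O)OC1CCC(CN2CCN(c3cc(=O)c4cc(C(F)(F)F)cc([N+](=O)[O-])c4s3)CC2)CC1` differs from it by methyl in place of 4-methylphenyl on a carbonyl carbon. Going by the values given here, the one measured step, an at least 7.6-fold lower number from compound 1 to compound 2 (0.88 log units; beyond the scatter), put ((4-methylphenyl)carbonyl)oxy in place of methanesulfonamido. Among the compounds with values here, compound 3 keeps the carbonyl and its oxygen, and no measured step touches 4-methylphenyl alone, so only a small change in this assay is expected, in either direction. The expected step is a 1.2-fold higher number from compound 2 to compound 3 (0.09 log units; within the scatter). Compound 3 is estimated at 0.25 h, with an expected range of 0.08 h to 0.7 h.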

Compound 3, half-life: < 0.15 h
Compound 3: only a limit was reported (the forecaster's own chance of this, stated with the estimate: 8%); middle value at least 1.6-fold (0.22 log units) from the limit.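

In this assay, compound 3 gives only a limit, not a number, < 0.15 h: the limit of < 0.15 h in this assay, at which 1 of the 3 values shown sits. Trimming 4-methylphenyl to methyl on the carbonyl carbon brings no recovery of the half-life, with an at least 1.3-fold lower number from compound 2 to compound 3 (0.12 log units; that floor lies within the scatter), so the true size of this step stays unsettled. Acetoxy in place of methanesulfonamido gives an at least 10-fold lower number from compound 1 to compound 3 (1.01 log units; beyond the scatter), so the small acetoxy group, like the larger ((4-methylphenyl)carbonyl)oxy group, falls well short of methanesulfonamido.

Still open, on these data alone, is how an acetamido group or a plain hydroxyl on the same saturated ring carbon would compare. As far as these compounds go, the real half-life of compound 3 also remains unknown.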